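The source may hold more compounds than are shown below. What is called first, only, known or untested is meant among the compounds shown, and "the series" means these compounds.

Compound 1 `Cc1ccc(NC(=O)Nc2cc(C)nc3ccccc23)cc1`, compound 2 `CC(=O)c1ccc(NC(=O)Nc2cc(C)nc3ccccc23)cc1` and compound 3 `Cc1cc(NC(=O)Nc2ccc(N(C)C)cc2)c2ccccc2n1` share one core and differ only in one group on the outer ring. In an ADME assay on HEK293 cells (Homo sapiens) for cytotoxicity, with a stated time of 72 h (a higher number here means that more compound is needed for the effect, a lower number that less compound is needed), compound 1 gives > 25000 nM, a limit of the assay. In this assay compound 2 gives > 25000 nM, again a limit. Compound 3 gives > 25000 nM, also a limit, so it stands at the limit of > 25000 nM in this assay, at which 3 of the 3 values shown sit. Between the three lie a step that the two limits leave unreadable from compound 1 to compound 2, a step that the two limits leave unreadable from compound 1 to compound 3 and a step that the two limits leave unreadable from compound 2 to compound 3. Compound 4 `Cc1cc(NC(=O)Nc2ccc(C(F)(F)F)cc2)c2ccccc2n1` differs from compound 3 by trifluoromethyl in place of dimethylamino on an aromatic carbon. Among the compounds with values here, no measured step reads out a size for such a change, and every value so far sits at the limit, so no step beyond the scatter is expected in this assay. Compound 4 is therefore expected to give 30000 nM, within 12000 nM to 100000 nM. The step that the limit leaves unreadable from compound 3 to compound 4 is thus expected.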

Compound 4, half-maximal effective concentration: 25000 nM
Compound 4: the middle estimate sits 1.2-fold (0.08 log units) above what was measured; measured number inside the range.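

In this assay, within the data shown here, compound 4 gives 25000 nM, the first plain number for this position on the outer ring. Compound 1, compound 2 and compound 3 each stand at a limit of the assay: the limit of > 25000 nM in this assay, at which 3 of the 4 values shown sit. Trifluoromethyl in place of dimethylamino gives a number no higher from compound 3 to compound 4 (the limit leaves the size open) and trifluoromethyl in place of acetyl gives a number no higher from compound 2 to compound 4 (the limit leaves the size open) and trifluoromethyl in place of methyl gives a number no higher from compound 1 to compound 4 (the limit leaves the size open) while the sizes of all three steps cannot be read.

The compounds shown leave open whether any group here gives a number clearly lower in this assay. From the compounds shown here alone, a carboxylic acid, a primary amine or a longer chain at this position remains untested among them.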